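Bromine on the Benzyl Ring of an Inactive Nitro Chalcone

The compounds below may be only part of what the source reports. "The series", "measured", "known", "first", "only" and "open" are said of these compounds alone.

Measured so far:
Compound 1 `COc1ccc(C(=O)/C=C/c2ccc(OCc3cn(Cc4ccccc4)nn3)cc2)cc1` gives 51% in a functional assay on HepG2 cells (Homo sapiens) for inhibition, read by MTT assay, with a stated time of 48 h, tested at 10 uM; on this read-out higher numbers stand for more inhibition of growth at the one concentration tested and lower numbers for less inhibition of growth.
Compound 2 `O=C(/C=C/c1ccc(OCc2cn(Cc3ccccc3)nn2)cc1)c1ccc([N+](=O)[O-])cc1` gives "not active" (no number reported) in this assay.

Compound 2 stands without a single number: in this assay it is reported only as not active, whereas compound 1, which carries a methoxy group where compound 2 carries a nitro group, gives a measurable percentage. No step between measured compounds that differ in one place is available, so nothing has been shown about how a change on the benzyl group moves the read-out.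

Compound 3 `O=C(/C=C/c1ccc(OCc2cn(Cc3ccc(Br)cc3)nn2)cc1)c1ccc([N+](=O)[O-])cc1` differs from compound 2 in one place: bromo in place of hydrogen on an aromatic carbon, in words bromo in place of hydrogen on an aromatic carbon. Because compound 2 gives "not active" (no number reported), no numerical step can be expected; the expected change is none beyond the usual scatter. Compound 3 is therefore estimated at 15%, with a range from 0% to 40%.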

Compound 3, percent growth inhibition at one concentration: 21%
Compound 3: the middle estimate sits 6 percentage points below what was measured; the range from low to high includes it.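

Within the data shown here, compound 2 has no number in this assay to start from, so no step to compound 3 can be read. Nothing measured here explains the value of compound 3. The compounds shown leave open how far bromo in place of hydrogen moves growth inhibition.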